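Changing the group on sulfur in compound 3

The source may report more compounds than this note shows. Statements on the series, on what has been measured and on what is new or still open speak of the compounds shown alone.

In a functional assay on PC-3 cells (Homo sapiens) for inhibition, read by MTT assay, with a stated time of 72 h (a higher number here means a weaker inhibitor, a lower number a stronger inhibitor), compound 1 `CC(C)(C)OC(=O)N1CCN(c2cc(C(F)(F)F)nc(SCc3ccc(C(F)(F)F)cc3)n2)CC1` gives 40600 nM. Compound 2 `Cc1csc(Sc2cc(C(F)(F)F)nc(SCc3ccc(C(F)(F)F)cc3)n2)n1` gives 12000 nM. Compound 3 `FC(F)(F)c1ccc(CSc2nc(Sc3ncccn3)cc(C(F)(F)F)n2)cc1` returns only a limit of the assay, > 50000 nM, and no number. Its standing is thus known from one side only: the limit of > 50000 nM in this assay, at which 1 of the 3 values shown sits.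

Compound 4 `FC(F)(F)c1ccc(CSc2nc(SC3=NCCS3)cc(C(F)(F)F)n2)cc1` keeps the rest of compound 3 and changes only the group on the sulfur: a group of 5 heavy atoms (3 carbon, 1 nitrogen, 1 sulfur; one five-membered non-aromatic ring with 2 hetero atoms) in place of a group of 6 heavy atoms (4 carbon, 2 nitrogen; one six-membered aromatic ring with 2 hetero atoms), on a sulfur.

Going by the values given here, one measured step bears on this change, at the same place: an at least 4.1-fold higher number from compound 2 to compound 3 (0.61 log units; beyond the scatter). That step lies beyond the scatter, and its true size is open because it ends on a limit. It brought in pyrimidin-2-yl in place of 4-methyl-1,3-thiazol-2-yl. The entering group again has a five-membered ring with sulfur and nitrogen among its atoms, but this ring is non-aromatic. On this single comparison with compound 2, at 12000 nM, a partial return toward a lower number in this assay is expected. A result that again reads only as a limit remains quite possible. The expected change is an at least 1.7-fold lower number from compound 3 to compound 4 (0.25 log units; that floor lies within the scatter). For compound 4 the estimated value is 28000 nM, with an expected range of 10000 nM to 70000 nM.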

Compound 4, half-maximal inhibitory concentration: 40600 nM
Estimate against measurement, compound 4: 1.5-fold (0.16 log units) below; low and high end bracket the measured number.
By their numbers in this assay, from the lowest: compound 2; then compounds 1 and 4 (each within the scatter of the next). At a limit, above all of these: compound 3.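

The non-aromatic five-membered ring on this sulfur gives a measured number in this assay, and the step from the pyrimidin-2-yl group reads as an at least 1.2-fold lower number from compound 3 to compound 4 (0.09 log units; that floor lies within the scatter), so any gain over that group may be no larger than the usual scatter. Going by these compounds, compound 3 remains a limit of the assay and not a number, so the true size of that step stays unknown: the limit of > 50000 nM in this assay, at which 1 of the 4 values shown sits. The aromatic 4-methyl-1,3-thiazol-2-yl group still holds the advantage at this place, with a 3.4-fold higher number from compound 2 to compound 4 (0.53 log units; beyond the scatter), although this step changes the ring from aromatic to non-aromatic and also removes the methyl group, so it cannot separate those two changes.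

Still open, on these data alone, is how a thiazol-2-yl group without the methyl group would read, and whether a methyl group on the non-aromatic ring would move the number. Also open, as far as these compounds go, is how a simple alkyl chain or an amine-bearing group on this sulfur would read, and whether any such group gives a lower number than compound 2 at 12000 nM.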